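Pyrazole hydrazone series: methoxy for chloro on the aryl arm

A few compounds are considered here, and "the series" means these few. Any claim that something is new, unique, unknown or untested is made for them only; others in the source may bear on it.

Working notes. The series shares one core; compound 1 `C/C(=N\NC(=O)c1cc(-c2ccccc2)nn1Cc1ccc(C(C)(C)C)cc1)c1cc(C)ccc1O` carries an unsubstituted phenyl on it and in a functional assay on A549 cells (Homo sapiens) for inhibition, read by MTT assay, with a stated time of 48 h (a lower number here means a stronger inhibitor, a higher number a weaker inhibitor), compound 1 gives 6100 nM. Compound 2 `C/C(=N\NC(=O)c1cc(-c2ccc(Cl)cc2)nn1Cc1ccc(C(C)(C)C)cc1)c1cc(C)ccc1O` carries the chlorinated phenyl and in this assay compound 2 gives 2490 nM, the lowest of the three numbers. Compound 3 `C/C(=N\NC(=O)c1cc(-c2ccc(Cl)cc2)nn1Cc1ccc(C(C)(C)C)cc1)c1cc(Cl)cc(Cl)c1O` changes the hydrazone side and in this assay compound 3 gives 7900 nM. The two measured steps are a 2.4-fold lower number from compound 1 to compound 2 (0.39 log units; beyond the scatter) and a 3.2-fold higher number from compound 2 to compound 3 (0.50 log units; beyond the scatter).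

Compound 4 `COc1ccc(-c2cc(C(=O)N/N=C(\C)c3cc(C)ccc3O)n(Cc3ccc(C(C)(C)C)cc3)n2)cc1` is compound 2 with methoxy in place of chloro on an aromatic carbon. For the measured compounds named here, only the step from compound 1 to compound 2 bears on this position, and it tells what hydrogen against chloro does, not methoxy against chloro. Going by the values given here, no measured pair covers methoxy here. The expected step of a 1.8-fold higher number from compound 2 to compound 4 (0.26 log units; within the scatter) in this assay is therefore set at a modest rise, placing compound 4 between compound 2 and compound 1, with wide uncertainty. Compound 4 is estimated at 4500 nM, range 1800 nM to 11000 nM.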

Compound 4, half-maximal inhibitory concentration: 10400 nM
Estimate against measurement, compound 4: 2.3-fold (0.36 log units) below; the measured number falls inside the stated range.
By their numbers in this assay, from the lowest: compound 2; then compounds 1, 3 and 4 (each within the scatter of the next).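

At this position, para to a large group, going from 4-chlorophenyl to 4-methoxyphenyl gives a 4.2-fold higher number from compound 2 to compound 4 (0.62 log units; beyond the scatter) in this assay, so the lower number of compound 2 is tied to chloro and does not carry over to methoxy. Against the unsubstituted phenyl, methoxy gives a 1.7-fold higher number from compound 1 to compound 4 (0.23 log units; within the scatter), so of the two substituents shown, only chloro moves the number beyond the scatter from hydrogen, as in a 2.4-fold lower number from compound 1 to compound 2 (0.39 log units; beyond the scatter). Nothing available accounts for the difference between chloro and methoxy here.

From the compounds shown here alone, whether the step from chloro to methoxy holds alongside the 3,5-dichloro-2-hydroxyphenyl of compound 3 remains open. Also open, going by these compounds, is how other groups at this position, such as bromo, an amine or a carboxylic acid, would compare with chloro in this assay.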